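Swapping Bromine for Chlorine on Two Related Cores

This account rests on a few compounds, and the source may have more. Where it says the series, first, only, none or still open, it means among the compounds named here.

Compound 1 `COC(=O)[C@@]1(C)CCC=C2[C@@H]1CC[C@@H](C)[C@]2(C)Cc1c(C)[nH]c2c(Br)cccc12` and compound 2 `COC(=O)[C@@]1(C)CCC=C2[C@@H]1CC[C@@H](C)[C@]2(C)Cc1c(C)[nH]c2c(Cl)cccc12` share one core. In a functional assay on A549 cells (Homo sapiens) for inhibition, read by sulforhodamine B assay, with a stated time of 48 h (a higher number here means a weaker inhibitor of growth, a lower number a stronger inhibitor of growth), compound 1 gives 27000 nM, and compound 2 gives 20000 nM. The change between them is chloro in place of bromo on an aromatic carbon, and a 1.4-fold lower number from compound 1 to compound 2 (0.13 log units; within the scatter). Compound 3 `COC(=O)[C@@]1(C)CC[C@@H]2C3=C1CC[C@@H](C)[C@]3(C)C[C@@H]1c3cc(Br)ccc3N[C@H]21` is built on a different core; the difference between the two cores is not broken down here. In this assay compound 3 gives 40000 nM. Compound 4 `COC(=O)[C@@]1(C)CC[C@@H]2C3=C1CC[C@@H](C)[C@]3(C)C[C@@H]1c3cc(Cl)ccc3N[C@H]21` has not been measured. It differs from compound 3 by chloro in place of bromo on an aromatic carbon, the same kind of change, though here the place is meta to a fused ring and para to a fused ring in a fused or bridged system of five rings, whereas for compound 2 it is ortho to a fused ring and meta to a fused ring in a system of two rings. Because a 1.4-fold lower number from compound 1 to compound 2 (0.13 log units; within the scatter), a similar small step is expected: a 1.4-fold lower number from compound 3 to compound 4 (0.14 log units; within the scatter). Compound 4 is therefore estimated at 29000 nM, likely between 15000 nM and 60000 nM.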

Compound 4, concentration for 50% growth inhibition: 35000 nM
Compound 4: middle estimate off by 1.2-fold (0.08 log units), on the low side; the measured number falls inside the stated range.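

In this assay, chloro in place of bromo on an aromatic carbon gives a 1.1-fold lower number from compound 3 to compound 4 (0.06 log units; within the scatter). Set beside the earlier step, the change behaves alike on the two cores: the same change on two cores in this assay, a 1.4-fold lower number (0.13 log units; within the scatter) from compound 1 to compound 2 and a 1.1-fold lower number (0.06 log units; within the scatter) from compound 3 to compound 4, 1.2-fold (0.07 log units) apart, within the scatter of two such steps. This shows only that swapping these two halogens leaves the number within the scatter on both cores, and two small steps cannot show that a larger effect of a change would carry from one core to the other.

The compounds shown leave open whether a different group on the same aromatic carbon, such as a methoxy group, an amine or a carboxylic acid, would move the number beyond the scatter. They also leave open whether any such step would match on both cores.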